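Adding a Nitro Group Where Potency Already Sits at the Limit

This account rests on a few compounds, and the source may have more. Where it says the series, first, only, none or still open, it means among the compounds named here.

Of the compounds shown here, three have been measured in a functional assay on CCRF-CEM cells (Homo sapiens) for antiproliferative activity, with a stated time of 72 h; a lower number here means a stronger inhibitor, a higher number a weaker inhibitor. Compound 1 `COc1ccc(-n2c(-c3cc(OC)c(OC)c(OC)c3)csc2=N)cc1` gives 13200 nM, and compound 2 `COc1ccc(-n2c(-c3cc(OC)c(OC)c(OC)c3)csc2=O)cc1` gives 14900 nM; the two lie within the scatter of each other. For compound 3 `COc1ccc(-c2c(Cl)sc(=O)n2-c2cc(OC)c(OC)c(OC)c2)cc1` the read-out is a limit, not a number, > 20000 nM; this is the limit of > 20000 nM in this assay, at which 1 of the 3 values shown sits. Compound 4 `COc1ccc(-c2c(Cl)sc(=O)n2-c2cc(OC)c(OC)c(OC)c2)cc1[N+](=O)[O-]` differs from compound 3 by a nitro in place of hydrogen on an aromatic carbon. Compound 3 already stands at the edge of what this assay can resolve, and no measured step among these compounds guides this change. The step expected is a number no higher from compound 3 to compound 4 (the limit leaves the size open), none beyond the scatter, with a real chance that only a limit is returned again. Compound 4 is expected to give 20000 nM in this assay, between 10000 nM and 40000 nM.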

Compound 4, half-maximal inhibitory concentration: 7500 nM
Compound 4: middle estimate off by 2.7-fold (0.43 log units), on the high side; measured number below the stated range.
By their numbers in this assay, from the lowest: compounds 4, 1 and 2 (each within the scatter of the next). At a limit, above all of these: compound 3.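

In this assay, a nitro in place of hydrogen on an aromatic carbon, ortho to a methoxy group, gives an at least 2.6-fold lower number from compound 3 to compound 4 (0.42 log units; beyond the scatter). This shows that the position can carry a group of this size and that a change there can bring a compound back within the measurable range. The true size of the step stays unknown because the value for compound 3 is a limit: the limit of > 20000 nM in this assay, at which 1 of the 4 values shown sits.

As far as these compounds go, whether the gain belongs to the nitro itself remains open. An amine or a nitrile at the same position would help to settle that.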